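A few compounds are considered here, and "the series" means these few. Any claim that something is new, unique, unknown or untested is made for them only; others in the source may bear on it.

The measured compounds and their values:

compound 1 `Cc1ccc(NC(=O)NC(=O)c2ccc(OCc3ccc(C(F)(F)F)cc3)cc2)cc1-c1nc2ccccc2[nH]1` 7830 nM
compound 2 `Cc1ccc(NC(=O)NC(=O)c2ccc(OCc3ccccc3Cl)cc2)cc1-c1nc2ccccc2[nH]1` 9010 nM

In a functional assay on HT-29 cells (Homo sapiens) for inhibition, read by MTT assay, with a stated time of 48 h (a lower number here means a stronger inhibitor, a higher number a weaker inhibitor), compound 1 gives 7830 nM and compound 2 gives 9010 nM. Compound 2 holds the higher of the two numbers, but a 1.2-fold higher number from compound 1 to compound 2 (0.06 log units; within the scatter) keeps it within the scatter of compound 1. Compound 3 `Cc1ccc(NC(=O)NC(=O)c2ccc(OCc3ccc(Cl)cc3Cl)cc2)cc1-c1nc2ccccc2[nH]1` differs from compound 2 by chloro in place of hydrogen on an aromatic carbon, meta to a chloro group and para to a large group. Going by the values given here, the only step that bears on it, from compound 1 to compound 2, exchanged one substituted benzyl group for another and was small. Compound 3 is therefore expected to show no step beyond the scatter in this assay, a 1.1-fold lower number from compound 2 to compound 3 (0.03 log units; within the scatter). The estimate for compound 3 is 8500 nM, ranging from 3500 nM to 20000 nM.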

Compound 3, half-maximal inhibitory concentration: 2620 nM
Compound 3: middle estimate off by 3.2-fold (0.51 log units), on the high side; the measured number lies below the stated range.
By their numbers in this assay, from the lowest: compound 3; then compounds 1 and 2 (each within the scatter of the next).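

In this assay, chloro on this aromatic carbon, para to a large group, gives a 3.4-fold lower number from compound 2 to compound 3 (0.54 log units; beyond the scatter), so the carbon responds to substitution in a way the earlier exchange of one benzyl group for another did not show. The 2,4-dichlorophenyl group likewise gives a 3.0-fold lower number from compound 1 to compound 3 (0.48 log units; beyond the scatter), so the two chloro groups together stand apart from the 4-(trifluoromethyl)phenyl group. No measurement at hand gives a reason for these steps. The compounds shown leave open whether chloro on this carbon would give the same step without the second chloro group. They also leave open how a methoxy group or an amine would compare there.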